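This account rests on a few compounds, and the source may have more. Where it says the series, first, only, none or still open, it means among the compounds named here.

Working notes on the series.

Compound 1 `CCn1c(C(=O)NCCNC(=O)OC(C)(C)C)ccc1C(CC)(CC)c1ccc(OCS(=O)(=O)c2ccccc2)c(C)c1` gives only a limit of the assay in a functional assay on PC-3 cells (Homo sapiens) for antiproliferative activity, read by MTT assay, with a stated time of 24 h (a higher number here means a weaker inhibitor, a lower number a stronger inhibitor), > 50000 nM; this is where compound 1 stands, as recorded in the limit of > 50000 nM in this assay, at which 1 of the 3 values shown sits, so its true value is known only as a bound. Compound 2 `CCn1c(C(=O)NC(C)(C)CO)ccc1C(CC)(CC)c1ccc(OCS(=O)(=O)c2ccccc2)c(C)c1` gives 9850 nM in this assay. Compound 3 `CCn1c(C(=O)NCCCO)ccc1C(CC)(CC)c1ccc(OCS(=O)(=O)c2ccccc2)c(C)c1` gives 11300 nM in this assay. The two measured steps from compound 1 both carry hydroxyl-bearing groups on the amide-type nitrogen: an at least 5.0-fold lower number from compound 1 to compound 2 (0.70 log units; beyond the scatter) and an at least 4.4-fold lower number from compound 1 to compound 3 (0.64 log units; beyond the scatter). Between the two hydroxyl-bearing amides, a 1.1-fold higher number from compound 2 to compound 3 (0.06 log units; within the scatter).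

Compound 4 `CCn1c(C(=O)N[C@H](CO)CCO)ccc1C(CC)(CC)c1ccc(OCS(=O)(=O)c2ccccc2)c(C)c1` differs from compound 1 in the same place: 3-hydroxy-1-(hydroxymethyl)propyl in place of 2-((tert-butoxycarbonyl)amino)ethyl on an amide-type nitrogen. The entering group carries hydroxyl substitution, as in compound 2 and compound 3, so the steps from compound 1 to compound 2 and from compound 1 to compound 3 bear on it, and a step of at least modest size toward a lower number is expected, as an at least 5.0-fold lower number from compound 1 to compound 4 (0.69 log units; beyond the scatter). Compound 4 is therefore estimated at 10000 nM in this assay, in a range from 4000 nM to 30000 nM.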

Compound 4, half-maximal inhibitory concentration: 12100 nM
For compound 4 the middle estimate is 1.2-fold (0.08 log units) below the measured one; measured number inside the range.
By their numbers in this assay, from the lowest: compounds 2, 3 and 4 (each within the scatter of the next). At a limit, above all of these: compound 1.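

The hydroxymethyl in place of hydrogen on the saturated chain carbon bound to the amide-type nitrogen gives no readable difference in this assay: a 1.1-fold higher number from compound 3 to compound 4 (0.03 log units; within the scatter), and likewise a 1.2-fold higher number from compound 2 to compound 4 (0.09 log units; within the scatter). The step away from 2-((tert-butoxycarbonyl)amino)ethyl also holds for 3-hydroxy-1-(hydroxymethyl)propyl, an at least 4.1-fold lower number from compound 1 to compound 4 (0.61 log units; beyond the scatter). The true size of that step stays unknown because compound 1 is recorded only as a limit: the limit of > 50000 nM in this assay, at which 1 of the 4 values shown sits.

Open, going by these compounds, is whether an amine or a carboxylic acid on this nitrogen would read with compound 2, compound 3 and compound 4, or with compound 1. Also open, on these data alone, is how the opposite configuration at the defined stereocentre of compound 4 would read.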